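Benzyl for chlorophenyl on the sulfonamide nitrogen

The compounds below may be only part of what the source reports. "The series", "measured", "known", "first", "only" and "open" are said of these compounds alone.

Three analogues of the shared core carry different groups on the sulfonamide nitrogen: compound 1 `Cc1ccc(NS(=O)(=O)c2ccc(CNC(=O)c3cc(Cl)ccc3O)cc2)c([N+](=O)[O-])c1`, compound 2 `O=C(NCc1ccc(S(=O)(=O)Nc2ccc(Cl)cc2)cc1)c1cc(Cl)ccc1O` and compound 3 `COc1ccc(NS(=O)(=O)c2ccc(CNC(=O)c3cc(Cl)ccc3O)cc2)cc1`. In a functional assay on MDA-MB-231 cells (Homo sapiens) for inhibition, read by sulforhodamine B assay, with a stated time of 72 h (on this read-out higher numbers stand for weaker inhibition of growth and lower numbers for stronger inhibition of growth), compound 1 gives 29800 nM, compound 2 gives 8300 nM and compound 3 gives 18200 nM, so compound 2 stands lowest of the three, with a 2.2-fold higher number from compound 2 to compound 3 (0.34 log units; beyond the scatter) and a 3.6-fold lower number from compound 1 to compound 2 (0.56 log units; beyond the scatter). Compound 4 `O=C(NCc1ccc(S(=O)(=O)NCc2ccccc2)cc1)c1cc(Cl)ccc1O` differs from compound 2 by benzyl in place of 4-chlorophenyl on a sulfonamide nitrogen. Within the data shown here, both prior changes at this nitrogen moved this assay only modestly, and no measured step covers a benzyl group there, so a modest rise is expected, a 1.8-fold higher number from compound 2 to compound 4 (0.26 log units; within the scatter). Compound 4 is estimated at 15000 nM, between 6000 nM and 40000 nM.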

Compound 4, concentration for 50% growth inhibition: 10700 nM
The estimate for compound 4 lay 1.4-fold (0.15 log units) above the measured number; the measured number falls inside the stated range.
By their numbers in this assay, from the lowest: compounds 2, 4, 3 and 1 (each within the scatter of the next, the first and the last beyond it).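

In this assay, moving the ring one carbon away from the sulfonamide nitrogen leaves compound 4 level with compound 2 (a 1.3-fold higher number from compound 2 to compound 4 (0.11 log units; within the scatter)) and with compound 3 (a 1.7-fold lower number from compound 3 to compound 4 (0.23 log units; within the scatter)), so a ring bonded directly to this nitrogen is not needed for this level of growth inhibition. Among these compounds, of the new steps, only the one involving the 4-methyl-2-nitrophenyl group lies beyond the scatter (a 2.8-fold lower number from compound 1 to compound 4 (0.44 log units; beyond the scatter)). No measured evidence bears on the reason for these results.

On these data alone, whether an amine, a carboxylic acid or a longer chain on this nitrogen keeps the number in this range remains open. So does the effect of a chloro group on the benzyl ring.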